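Dropping One Methoxy Group: Expected Cytotoxicity

A few compounds are considered here, and "the series" means these few. Any claim that something is new, unique, unknown or untested is made for them only; others in the source may bear on it.

Of the compounds shown here, two have been measured so far. Compound 1 `COc1cc(-c2cc(/C=C/C(=O)c3ccc(N)cc3)[nH]n2)cc(OC)c1OC` carries several methoxy groups on one outer ring and an amino group on the other. In a functional assay on SF-295 cells (Homo sapiens) for cytotoxicity, read by sulforhodamine B assay, with a stated time of 48 h, tested at 10 uM (on this read-out lower numbers stand for a stronger effect and higher numbers for a weaker effect at the one concentration tested), compound 1 gives 4%. Compound 2 `COc1ccc(-c2cc(/C=C/C(=O)c3ccc(OC)c(OC)c3)[nH]n2)cc1` is a differently decorated relative, and in this assay compound 2 gives -33%. Of these two numbers compound 1 holds the higher one, and its gap to compound 2 lies beyond the usual scatter, so compound 1 shows the weaker effect of the pair. Compound 3 `COc1ccc(-c2cc(/C=C/C(=O)c3ccc(N)cc3)[nH]n2)cc1OC` differs from compound 1 in one place: hydrogen in place of methoxy on an aromatic carbon. For the measured compounds named here, the two measured compounds are not related by a single change, so no measured step points the way. With just one methoxy group gone, the step of a number 4 percentage points higher from compound 1 to compound 3 (within the scatter) is expected to stay within the scatter. Compound 3 is therefore estimated at 8%, with a likely range from -15% to 35%.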

Compound 3, a percentage reported as activity, at one concentration (the size of the read-out at that concentration, not a potency): 20%
Compound 3: the middle estimate sits 12 percentage points below what was measured; low and high end bracket the measured number.
By their numbers in this assay, from the lowest: compound 2; then compound 1; then compound 3.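

For the compounds shown here, this is the first single change that can be read. In this assay, putting hydrogen in place of methoxy on this aromatic carbon gives a number 16 percentage points higher from compound 1 to compound 3 (beyond the scatter). A higher number stands for a weaker effect, and the loss of this methoxy group modestly weakens the effect. The position, ortho to a methoxy group and meta to a large group, is therefore not indifferent to this change, although nothing available explains why the read-out moves.

The compounds shown leave open how a hydroxyl group, a fluorine atom or a longer ethoxy chain on this same carbon would compare with methoxy and hydrogen. They also leave open whether the step would be the same size if the amino group on the other outer ring were replaced.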